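The compounds below may be only part of what the source reports. "The series", "measured", "known", "first", "only" and "open" are said of these compounds alone.

Compound 1 `COc1ccc(C(F)(F)F)cc1CO[C@H]1[C@H](C(C)(C)C)[C@@H](C(=O)O)N(C(=O)C2CCCCC2)[C@H]1c1ccccc1` gives 173 nM in an assay on cells with Cystic fibrosis transmembrane conductance regulator variant F508del (Homo sapiens) as the target, read by voltage clamp, with a stated time of 24 h, in the presence of a further agent that is not named here; a higher number here means that more compound is needed for the effect, a lower number that less compound is needed; compound 2 `COc1ncc(C(F)(F)F)cc1CO[C@H]1[C@H](C(C)(C)C)[C@@H](C(=O)O)N(C(=O)C2CCCCC2)[C@H]1c1ccccc1` gives 150 nM.

Compound 2 stands at the lowest of the two numbers, with compound 1 nearest; the step of a 1.2-fold lower number from compound 1 to compound 2 (0.06 log units; within the scatter) lies within the scatter. Compound 3 `COc1ncc(C2CCCC2)cc1CO[C@H]1[C@H](C(C)(C)C)[C@@H](C(=O)O)N(C(=O)C2CCCCC2)[C@H]1c1ccccc1` carries a single change from compound 2: cyclopentyl in place of trifluoromethyl on an aromatic carbon. Among the measured compounds shown here, no measured step touches that position, so the one step known, from compound 1 to compound 2, does not bear on it. With no guide, the expected step of a 1.5-fold higher number from compound 2 to compound 3 (0.17 log units; within the scatter) is set near nothing beyond the scatter, and compound 3 is estimated at 220 nM, between 60 nM and 800 nM.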

Compound 3, half-maximal effective concentration: 247 nM
Compound 3: middle estimate off by 1.1-fold (0.05 log units), on the low side; the measured number falls inside the stated range.
By their numbers in this assay, from the lowest: compounds 2, 1 and 3 (each within the scatter of the next).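

In this assay, this position, on an aromatic carbon para to a methoxy group, now has its first reading: cyclopentyl in place of trifluoromethyl gives a 1.6-fold higher number from compound 2 to compound 3 (0.22 log units; within the scatter). A ring of five carbons can therefore replace the three fluorines and their carbon here with no step beyond the scatter. Nothing available offers an explanation for this reading.

The compounds shown leave open whether an amine or a longer alkyl chain at this place would also stay within the scatter of compound 2. They also leave open whether cyclopentyl would give a similar step on the core of compound 1.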